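The compounds below may be only part of what the source reports. "The series", "measured", "known", "first", "only" and "open" are said of these compounds alone.

Notes on the series

Measured so far in a functional assay on A-431 cells (Homo sapiens) for antiproliferative activity, read by MTT assay, with a stated time of 72 h; a higher number here means a weaker inhibitor, a lower number a stronger inhibitor:
compound 1 `COc1cc2ncnc(Nc3ccc(Cl)cc3)c2cc1OCCCCC(=O)Nc1ccc(S(N)(=O)=O)cc1` gives 7120 nM
compound 2 `COc1cc2ncnc(Nc3ccc(C)cc3)c2cc1OCCCCC(=O)Nc1ccc(S(N)(=O)=O)cc1` gives 35500 nM
compound 3 `NS(=O)(=O)c1ccc(NC(=S)Nc2ccc3ncnc(Nc4cccc(Cl)c4)c3c2)cc1` gives 15000 nM

Compound 1 and compound 2 share a core and differ in one place: methyl in place of chloro on an aromatic carbon. That change gave a 5.0-fold higher number from compound 1 to compound 2 (0.70 log units; beyond the scatter). Compound 3 sits on a different core; the difference between the two cores is not broken down here. Compound 4 `Cc1cccc(Nc2ncnc3ccc(NC(=S)Nc4ccc(S(N)(=O)=O)cc4)cc23)c1` is not yet measured and differs from compound 3 by methyl in place of chloro on an aromatic carbon. The surroundings are not identical: in compound 1 the group sits para to a large group, in compound 3 meta to a large group, so this is the same kind of change, not the same one. For compound 4 the expected step is a 3.3-fold higher number from compound 3 to compound 4 (0.52 log units; beyond the scatter), set beside the earlier one because the same kind of change gave a 5.0-fold higher number from compound 1 to compound 2 (0.70 log units; beyond the scatter). In this assay compound 4 is expected near 50000 nM, between 20000 nM and 120000 nM.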

Compound 4, half-maximal inhibitory concentration: 23800 nM
Estimate against measurement, compound 4: 2.1-fold (0.32 log units) above, and the stated range covers the measured number.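

In this assay, for the compounds shown here, methyl in place of chloro gave a 1.6-fold higher number from compound 3 to compound 4 (0.20 log units; within the scatter) and so no step that can be told apart from the scatter on this core. The result rests on one pair per core, and the group stands in different surroundings in the two pairs, so the data cannot separate the effect of the core from that of the group's place. What the pairs do show is that the size of the step did not carry over from one core to the other: the same change on two cores in this assay, a 5.0-fold higher number (0.70 log units; beyond the scatter) from compound 1 to compound 2 and a 1.6-fold higher number (0.20 log units; within the scatter) from compound 3 to compound 4, 3.1-fold (0.50 log units) apart, beyond the scatter of two such steps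

The compounds shown leave open whether fluoro, methoxy or trifluoromethyl in place of chloro would also give steps that differ between the two cores. They also leave open how the same change would read with the chloro and methyl groups in the same place on both cores.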